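The compounds below may be only part of what the source reports. "The series", "measured", "known", "first", "only" and "open" are said of these compounds alone.

Compound 1 `CNC(=O)c1cc(C(=O)NC2CC2)cn(CC2CCCOC2)c1=O` stands lowest of the three measured compounds in a physicochemical assay for lipophilicity, at pH 7.4 (on this read-out lower numbers stand for lower lipophilicity and higher numbers for higher lipophilicity), at 2. Compound 3 `CNC(=O)c1cc(C(=O)NC)c(=O)n(Cc2ccccc2)c1` gives 2.4, and compound 2 `CCNC(=O)c1cc(C(=O)NC)c(=O)n(Cc2ccccc2)c1` gives 3. For the measured compounds named here, the one measured step, a number 0.60 log units lower from compound 2 to compound 3 (beyond the scatter), concerns a saturated chain carbon bound to an amide-type nitrogen and so touches a different place than the change considered here. Compound 4 `CNC(=O)c1cc(C(=O)NC2CC2)cn(Cc2ccc(C)cc2)c1=O` differs from compound 1 by 4-methylphenyl in place of oxan-3-yl on a saturated chain carbon bound to an aromatic nitrogen. Going by the values given here, no measured pair shows this exchange; the group that enters carries no hydrogen-bond acceptor while the one that leaves carries one, and an aromatic ring of carbon only enters. A rise beyond the scatter is therefore expected, a number 1.20 log units higher from compound 1 to compound 4 (beyond the scatter), giving compound 4 an estimated 3.2, between 2.6 and 3.8.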

Compound 4, distribution coefficient: 3.5
Compound 4: the middle estimate sits 0.30 log units below what was measured; the measured number falls inside the stated range.
By their numbers in this assay, from the lowest: compound 1; then compound 3; then compound 2; then compound 4.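

Exchanging oxan-3-yl for 4-methylphenyl on a saturated chain carbon bound to an aromatic nitrogen gives, in this assay, a number 1.50 log units higher from compound 1 to compound 4 (beyond the scatter). For the compounds shown here, this is the first step measured at this place, and it shows that the group held there can move the number by a large amount, which the one earlier step, made at a different place, could not show. Nothing measured here gives a reason for this rise.

Still open, from the compounds shown here alone, is whether the ring oxygen leaving or the aromatic ring and its methyl entering accounts for more of the step. A cyclohexyl ring or a phenyl ring carrying a carboxylic acid at this place could help separate the two.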